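Chalcone dithiocarbamates on gastric cancer cells: a chlorophenyl swap

This account rests on a few compounds, and the source may have more. Where it says the series, first, only, none or still open, it means among the compounds named here.

Compound 1 `COc1ccc(/C=C/C(=O)c2ccc(OCCCSC(=S)N3CCN(C)CC3)cc2)cc1`: 19400 nM
Compound 2 `O=C(/C=C/c1cccnc1)c1ccc(OCCCSC(=S)N2CCCC2)cc1`: 19500 nM
Compound 3 `O=C(/C=C/c1cccs1)c1ccc(OCCCSC(=S)N2CCCCC2)cc1`: 41300 nM

Three compounds have been examined in a functional assay on MGC-803 cells (Homo sapiens) for inhibition, read by MTT assay, with a stated time of 72 h; a lower number here means a stronger inhibitor, a higher number a weaker inhibitor. Compound 2 stands second highest of the three numbers: its value sits within the scatter of compound 1, while compound 3 lies beyond the scatter above it, so compound 2 is the stronger inhibitor of that pair. Compound 4 `O=C(/C=C/c1ccc(Cl)cc1)c1ccc(OCCCSC(=S)N2CCCC2)cc1` awaits measurement. It differs from compound 2 in a single place: 4-chlorophenyl in place of pyridin-3-yl on a double-bonded chain carbon bound to a double-bonded chain carbon. Going by the values given here, no measured pair shows a change of this kind, so nothing on record sizes it. The step of a 1.3-fold lower number from compound 2 to compound 4 (0.11 log units; within the scatter) is expected to be small, not beyond the scatter, in either direction. Compound 4 is therefore expected to give 15000 nM in this assay, with a range from 5000 nM to 45000 nM.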

Compound 4, half-maximal inhibitory concentration: 34500 nM
The estimate for compound 4 lay 2.3-fold (0.36 log units) below the measured number; low and high end bracket the measured number.
By their numbers in this assay, from the lowest: compounds 1, 2, 4 and 3 (each within the scatter of the next, the first and the last beyond it).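

In this assay, going by these compounds alone, the pair gives the first one-place comparison at this position: a 1.8-fold higher number from compound 2 to compound 4 (0.25 log units; within the scatter). Exchanging pyridin-3-yl for 4-chlorophenyl on a double-bonded chain carbon bound to a double-bonded chain carbon therefore moves the number no further than the usual scatter, despite the loss of the ring nitrogen. Nothing on record explains the size of this step. On these data alone, whether a carboxylic acid or a dimethylamino group in place of the chlorine would produce a step beyond the scatter remains open. So does whether the same exchange would read alike with the other dithiocarbamate ends seen in compound 1 and compound 3.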